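A few compounds are considered here, and "the series" means these few. Any claim that something is new, unique, unknown or untested is made for them only; others in the source may bear on it.

Measured compounds:
- compound 1, `O=C(Nc1ccc2nc(NC(=O)C3CCCCC3)sc2c1)c1ccccc1C(F)(F)F`, giving 0.024 ug/mL in a functional assay on WI-38 VA13 cells (Homo sapiens) for cytotoxicity; a higher number here means that more compound is needed for the effect, a lower number that less compound is needed
- compound 2, `O=C(Nc1nc2ccc(N/C(S)=N/C3=CC4OCCOC4C=C3)cc2s1)C1CCCCC1`, giving 1.6 ug/mL in this assay
- compound 3, `O=C(Nc1ccc2nc(NC(=O)C3CCC3)sc2c1)c1c(Cl)cccc1Cl`, giving 0.013 ug/mL in this assay

Compound 3 has the lowest number of the three. Its nearest neighbour is compound 1, whose number sits within the usual scatter of compound 3, so the two cannot be ordered. Compound 2 lies far beyond the scatter and is the weakest of the set.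

Compound 4, `COc1ccc(Nc2nc3ccc(NC(=O)c4c(Cl)cccc4Cl)cc3s2)cc1`, has not yet been measured. It differs from compound 3 in one place: 4-methoxyphenyl in place of cyclobutylcarbonyl on a nitrogen on an aromatic ring. For the measured compounds named here, no pair of measured compounds shows this exact change, so its effect is not known from the numbers at hand. Compound 2 suggests that replacing the acyl group on this nitrogen can cost a great deal, although compound 2 also differs elsewhere. Compound 4 is therefore expected to need more compound than compound 3, with the step of a 12-fold higher number from compound 3 to compound 4 (1.06 log units; beyond the scatter) estimated to be beyond the scatter. The estimated value for compound 4 is 0.15 ug/mL, within a range from 0.02 ug/mL to 1.5 ug/mL.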

Compound 4, half-maximal effective concentration: 0.87 ug/mL
The estimate for compound 4 lay 5.8-fold (0.76 log units) below the measured number; the range from low to high includes it.
By their numbers in this assay, from the lowest: compounds 3 and 1 (each within the scatter of the next); then compounds 4 and 2 (each within the scatter of the next).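

On a nitrogen on an aromatic ring, putting 4-methoxyphenyl in place of cyclobutylcarbonyl gives a 67-fold higher number from compound 3 to compound 4 (1.83 log units; beyond the scatter) in this assay, with the rest of the molecule unchanged. For the compounds shown here, this is the first single-place measure of how much this position matters, and it shows that a large loss does not depend on the other differences carried by compound 2. The swap removes both the carbonyl and the four-membered ring and brings in a six-membered aromatic ring, and no measurement shown explains the size of the step.

A benzoyl group on the same nitrogen would keep the carbonyl while carrying an aromatic ring, so it could help separate those two parts of the change. Plain phenyl in place of 4-methoxyphenyl would test whether the methoxy group plays any part.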